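Step from compound 2 to compound 4 in the series

The compounds below may be only part of what the source reports. "The series", "measured", "known", "first", "only" and "open" are said of these compounds alone.

Measured in a functional assay on A549 cells (Homo sapiens) for antiproliferative activity, read by sulforhodamine B assay, with a stated time of 48 h; on this read-out lower numbers stand for stronger inhibition and higher numbers for weaker inhibition:
compound 1 `COc1cc(C(=O)/C=C\Nc2ccc(-c3nc4cc(OC)c(OC)c(OC)c4s3)cc2)c(Br)c(OC)c1OC`: 13600 nM
compound 2 `COc1cc(OC)c2sc(-c3ccc(N/C=C\C(=O)c4cc(OC)c(OC)c(OC)c4Br)c(C)c3)nc2c1`: 14000 nM
compound 3 `COc1cc(OC)c2sc(-c3ccc(N/C=C\C(=O)c4cc(OC)c(OC)c(OC)c4)c(C)c3)nc2c1`: 14400 nM

Compound 2 stands level with the other two compounds, as all three values lie within the scatter of one another. The change to compound 4 `COc1cc(C(=O)/C=C\Nc2ccc(-c3nc4cc(OC)c(OC)c(OC)c4s3)cc2C)c(Br)c(OC)c1OC` is methoxy in place of hydrogen on an aromatic carbon, ortho to two methoxy groups. Going by the values given here, no measured step makes this change. The nearest evidence is a 1.0-fold higher number from compound 2 to compound 3 (0.01 log units; within the scatter), which is a different change at another place and shows only that this one replacement leaves the number within the scatter. With so little to go on, no step beyond the scatter is expected in this assay, and no direction can be favoured. The expected step is no change at the digits printed from compound 2 to compound 4 (within the scatter). Compound 4 is estimated at 14000 nM, with an expected range of 6000 nM to 30000 nM.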

Compound 4, half-maximal inhibitory concentration: 10300 nM
Estimate against measurement, compound 4: 1.4-fold (0.13 log units) above, and the stated range covers the measured number.
By their numbers in this assay, from the lowest: compounds 4, 1, 2 and 3 (each within the scatter of the next).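

In this assay, methoxy in place of hydrogen, on the aromatic carbon ortho to two methoxy groups, gives a 1.4-fold lower number from compound 2 to compound 4 (0.13 log units; within the scatter), so this position carries a group of 2 heavy atoms without leaving the scatter. The methyl group gives the same reading, with a 1.3-fold lower number from compound 1 to compound 4 (0.12 log units; within the scatter), and so neither single change separates compound 4 from its neighbour in this assay. Nothing measured bears on why these two steps read as they do.

Whether any group at this aromatic carbon can move the number beyond the scatter remains open, since all the steps shown lie within it. An amine, a carboxylic acid or a longer chain such as butoxy at this place would be the next test of how much the position tolerates.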